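The source may hold more compounds than are shown below. What is called first, only, known or untested is meant among the compounds shown, and "the series" means these compounds.

Measured in a functional assay (plasma) for inhibition, with Homo sapiens as the target; a lower number here means a stronger inhibitor, a higher number a weaker inhibitor:
- compound 1 `O=C(O)Cc1ccc(CCC2C3CCC(O3)C2/C=N/NC(=O)Nc2ccccc2)cc1`: 688000 nM
- compound 2 `O=C(O)Cc1ccc(CC2C3CCC(O3)C2/C=N/NC(=O)Nc2ccccc2)cc1`: 310000 nM

Of these two, compound 2 has the lower number at 310000 nM, and its gap to compound 1 lies beyond the scatter. Both are weak inhibitors in this assay. Compound 3 `O=C(O)Cc1cccc(CC2C3CCC(O3)C2/C=N/NC(=O)Nc2ccccc2)c1` is not yet measured. It carries 3-(carboxymethyl)phenyl in place of 4-(carboxymethyl)phenyl on a saturated chain carbon bound to a saturated ring carbon. For the measured compounds named here, the series holds no measured step for such a change, so the direction is uncertain. A moderate gain is expected, with a 2.6-fold lower number from compound 2 to compound 3 (0.41 log units; beyond the scatter) as the estimated step. The estimate for compound 3 is 120000 nM, with an expected range of 20000 nM to 450000 nM.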

Compound 3, half-maximal inhibitory concentration: 370 nM
Beside the measured number, compound 3's estimate is 320-fold (2.51 log units) above it, and the stated range ends above it.
By their numbers in this assay, from the lowest: compound 3; then compound 2; then compound 1.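

On a saturated chain carbon bound to a saturated ring carbon, 3-(carboxymethyl)phenyl in place of 4-(carboxymethyl)phenyl gives an 840-fold lower number from compound 2 to compound 3 (2.92 log units; beyond the scatter) in this assay. The two groups hold the same atoms, so how the group is joined, not what it contains, separates these weak and strong inhibitors. No data here account for the size of this step. As far as these compounds go, it remains open whether 3-(carboxymethyl)phenyl gives a similar gain on the longer chain of compound 1. Also open, from the compounds shown here alone, is whether a tetrazole can stand in place of the carboxylic acid.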